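Methyl in Place of Fluoro: What Compound 3 May Give

The compounds below may be only part of what the source reports. "The series", "measured", "known", "first", "only" and "open" are said of these compounds alone.

Measured so far:
compound 1, `Cc1cccc(C)c1NNC(=O)CCc1ccccc1`, 900 nM
compound 2, `O=C(CCc1ccc(F)cc1)NNc1c(Cl)cncc1Cl`, 900 nM

In a functional assay on HEK293 cells for antagonist activity at P2X purinoceptor 7 (Homo sapiens), read by fluorescence, with a stated time of 2 h (a lower number here means a stronger inhibitor, a higher number a weaker inhibitor), compound 1 gives 900 nM and compound 2 gives 900 nM. For the measured compounds named here, compound 2 thus stands level with compound 1, the two values lying within the usual scatter, and no single-change step between them is available. Compound 3, `Cc1ccc(CCC(=O)NNc2c(Cl)cncc2Cl)cc1`, differs from compound 2 by methyl in place of fluoro on an aromatic carbon. Such a swap is expected to move this assay only a little, no farther than the scatter, in no clear direction. Compound 3 is therefore expected to give 900 nM, between 300 nM and 2700 nM. That corresponds to an expected step of no change at the digits printed from compound 2 to compound 3 (within the scatter).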

Compound 3, half-maximal inhibitory concentration: 1400 nM
Estimate against measurement, compound 3: 1.6-fold (0.19 log units) below, and the stated range covers the measured number.
By their numbers in this assay, from the lowest: compounds 1, 2 and 3 (each within the scatter of the next).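

In this assay, the change from 4-fluorophenyl to 4-methylphenyl gives a 1.6-fold higher number from compound 2 to compound 3 (0.19 log units; within the scatter), so methyl and fluoro cannot be told apart at this position. For the compounds shown here, this is the first single-change comparison, which compound 1 and compound 2 could not offer, since they differ in more than one place. No available evidence explains this result. As far as these compounds go, it remains open whether this position stays as undemanding with an amine, a carboxylic acid or a longer chain. A single swap between two small groups cannot settle that.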